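Swapping Trifluoromethyl for Fluoro in Compound 2

A few compounds are considered here, and "the series" means these few. Any claim that something is new, unique, unknown or untested is made for them only; others in the source may bear on it.

Measured in a functional assay on MCF7 cells (Homo sapiens) for antiproliferative activity, read by MTT assay, with a stated time of 72 h; a lower number here means a stronger inhibitor, a higher number a weaker inhibitor:
- Compound 1 `N#Cc1cccc(Nc2ccc3c(c2)S(=O)(=O)C=C3)c1`: > 10000 nM (a limit of the assay, not a number)
- Compound 2 `O=S1(=O)C=Cc2cccc(Nc3cccc(C(F)(F)F)c3)c21`: 750 nM
- Compound 3 `Cc1cc(C)cc(Nc2cccc3c2S(=O)(=O)C=C3)c1`: 8800 nM

Only two of these results are actual numbers. Compound 2, at 750 nM, has the lower of the two, and compound 3, at 8800 nM, lies beyond the scatter from it.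

The next compound to be tested is compound 4 `O=S1(=O)C=Cc2cccc(Nc3cccc(F)c3)c21`. It carries fluoro in place of trifluoromethyl on an aromatic carbon.

Within the data shown here, no measured pair of compounds tests this swap, so the expectation is tentative. It rests only on compound 2 at 750 nM and compound 3 at 8800 nM. A moderate rise in the number is expected in this assay, probably beyond the scatter, which would mean a weaker inhibitor. The expected change is a 2.7-fold higher number from compound 2 to compound 4 (0.43 log units; beyond the scatter). For compound 4 the estimated value is 2000 nM, with an expected range of 600 nM to 8000 nM.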

Compound 4, half-maximal inhibitory concentration: 1120 nM
Compound 4: middle estimate off by 1.8-fold (0.25 log units), on the high side; low and high end bracket the measured number.
By their numbers in this assay, from the lowest: compounds 2 and 4 (each within the scatter of the next); then compound 3. At a limit, above all of these: compound 1.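

At this place on the six-membered aromatic ring of carbon only, trifluoromethyl gives way to fluoro, four heavy atoms replaced by one, and this assay shows a 1.5-fold higher number from compound 2 to compound 4 (0.17 log units; within the scatter), so the two compounds cannot be told apart here. Among these compounds, this is the first direct reading of a single change, as no earlier pair differed in only one place. No measured property shown here bears on this step, so the result stands without an explanation.

As far as these compounds go, whether an amine, a carboxylic acid or a longer chain at this place would keep the number in the same range stays open. From the compounds shown here alone, compound 1 gives > 10000 nM, which is a limit of the assay, and the same swap on its core also stays open.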